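Chloro added to a benzoxaborole: cytotoxicity outlook

The compounds below may be only part of what the source reports. "The series", "measured", "known", "first", "only" and "open" are said of these compounds alone.

Compound 1 `OB1OCc2ccc(-n3cccc3Sc3ccc(Cl)cc3)cc21` and compound 2 `OB1OCc2ccc(-n3cccc3Sc3ccc(Cl)c(Cl)c3)cc21` share one core, while compound 3 `O=C(c1ccccc1)c1ccn(-c2ccc3c(c2)B(O)OC3)c1` and the not yet measured compound 4 `O=C(c1ccn(-c2ccc3c(c2)B(O)OC3)c1)c1ccccc1Cl` share another. The difference between the two cores is not broken down here.

In an ADME assay on L929 cells (Mus musculus) for cytotoxicity, read by resazurin assay, with a stated time of 72 h (on this read-out lower numbers stand for stronger inhibition and higher numbers for weaker inhibition), compound 1 gives only a limit of the assay, > 10 ug/mL. In this assay compound 2 likewise gives a limit, > 10 ug/mL. Compound 3 also gives a limit in this assay, > 10 ug/mL.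

The change from compound 1 to compound 2 is chloro in place of hydrogen on an aromatic carbon. Its step, a step that the two limits leave unreadable from compound 1 to compound 2, has no readable size because of the limit of > 10 ug/mL in this assay, at which 3 of the 3 values shown sit.

The same kind of change takes compound 3 to compound 4: chloro in place of hydrogen on an aromatic carbon. The surroundings differ: in the first pair the place is ortho to a chloro group and meta to a large group, whereas in the second pair it is ortho to a large group.

From compound 3 to compound 4 the expected step in this assay is a step that the limit leaves unreadable from compound 3 to compound 4, an expectation resting on compound 3 giving > 10 ug/mL and on the fact that (the limit of > 10 ug/mL in this assay, at which 3 of the 3 values shown sit). Compound 4 is therefore estimated at 20 ug/mL, likely reported as a limit again.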

Compound 4, half-maximal inhibitory concentration: > 10 ug/mL
Compound 4 was reported as a limit (the forecaster's own chance of this, stated with the estimate: 80%); the middle value lies beyond the limit too.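

The size of the change from compound 3 to compound 4 in this assay cannot be read, because both compounds give only a limit rather than a number: the limit of > 10 ug/mL in this assay, at which 4 of the 4 values shown sit.

The compounds shown leave open how strongly any of the four affects these cells, and whether adding chloro shifts that effect on either core.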